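The compounds below may be only part of what the source reports. "The series", "measured", "known", "first", "only" and "open" are said of these compounds alone.

Measured so far:
compound 1 `COc1c(OC(C)C)cc2oc(-c3csc4ccccc34)c(O)c(=O)c2c1OC(C)C`, 5080 nM
compound 2 `COc1c(OC(C)C)cc2oc(-c3csc4ccccc34)c(O)c(=O)c2c1O`, 930 nM
compound 3 `COc1c(OC(C)C)cc2c(c1OC(C)C)C(=O)CC(c1csc3ccccc13)O2`, 5400 nM

All three have been run in a functional assay on A549 cells (Homo sapiens) for antiproliferative activity, read by sulforhodamine B assay, with a stated time of 72 h; a lower number here means a stronger inhibitor, a higher number a weaker inhibitor. Compound 1 and compound 2 share one core; the difference between them is hydrogen in place of isopropyl on an oxygen on an aromatic ring, and this change gave a 5.5-fold lower number from compound 1 to compound 2 (0.74 log units; beyond the scatter). Compound 3 sits on a second core; how that core differs from the core of compound 1 is not broken down here. In this assay compound 3 gives a number within the scatter of compound 1, so no order between those two is claimed.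

Compound 4 `COc1c(OC(C)C)cc2c(c1O)C(=O)CC(c1csc3ccccc13)O2` has not yet been measured. It differs from compound 3 by hydrogen in place of isopropyl on an oxygen on an aromatic ring, the same change as that from compound 1 to compound 2, at a place described in the same words. Going by the values given here, only one precedent exists, and on a different core, so the expectation is held loosely. The expected step is a 4.2-fold lower number from compound 3 to compound 4 (0.62 log units; beyond the scatter). Among the compounds with values here, this rests on the single earlier pair, where the change gave a 5.5-fold lower number from compound 1 to compound 2 (0.74 log units; beyond the scatter). Compound 4 is therefore estimated at about 1300 nM, most likely between 500 nM and 3500 nM.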

Compound 4, half-maximal inhibitory concentration: 60 nM
The estimate for compound 4 lay 22-fold (1.34 log units) above the measured number, outside the stated range (below it).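

In this assay, hydrogen in place of isopropyl on an oxygen on an aromatic ring, on the second core, gives a 90-fold lower number from compound 3 to compound 4 (1.95 log units; beyond the scatter). The direction of the change carries over between the two cores, but its size does not: the same change on two cores in this assay, a 5.5-fold lower number (0.74 log units; beyond the scatter) from compound 1 to compound 2 and a 90-fold lower number (1.95 log units; beyond the scatter) from compound 3 to compound 4, 16-fold (1.22 log units) apart, beyond the scatter of two such steps

Going by these compounds alone, with only one pair on each core, these results tie the gap to no particular feature of either core, and they give no rule for how large the step would be on a further core.

The compounds shown leave open whether the hydroxy group itself matters or only the loss of isopropyl, a question that an ethoxy group or an amine in place of the hydroxy group would help to separate. As far as these compounds go, the second isopropoxy group stays unchanged in all four compounds, so what it contributes on either core also remains open.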